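Fluorophenyl to trifluoromethylphenyl: step to compound 3

The source may hold more compounds than are shown below. What is called first, only, known or untested is meant among the compounds shown, and "the series" means these compounds.

In a functional assay on U-251 cells (Homo sapiens) for antiproliferative activity, read by MTT assay, with a stated time of 24 h (a higher number here means a weaker inhibitor, a lower number a stronger inhibitor), compound 1 `COc1cc(OC)c(-c2coc3cc(OCc4ccc(F)cc4)ccc3c2=O)cc1OC` gives 3200 nM and compound 2 `COc1cc(OC)c(-c2coc3cc(OCc4cccc(F)c4)ccc3c2=O)cc1OC` gives 3510 nM. These two values lie within the scatter of each other, so compound 2 stands level with compound 1.

Compound 3 `COc1cc(OC)c(-c2coc3cc(OCc4ccc(C(F)(F)F)cc4)ccc3c2=O)cc1OC` has not yet been measured. Its difference from compound 2 is 4-(trifluoromethyl)phenyl in place of 3-fluorophenyl on a saturated chain carbon bound to an oxygen on an aromatic ring.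

Going by the values given here, only one measured step bears on this place: a 1.1-fold higher number from compound 1 to compound 2 (0.04 log units; within the scatter), with 3-fluorophenyl in place of 4-fluorophenyl. Among the compounds with values here, it exchanges one fluorophenyl for another, and no trifluoromethyl example has been measured, so the support is thin. No step beyond the scatter is expected in this assay, and no direction is favoured.

The estimated step is a 1.1-fold lower number from compound 2 to compound 3 (0.03 log units; within the scatter). For compound 3 the expected value is 3300 nM, with an estimated range of 1500 nM to 7000 nM.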

Compound 3, half-maximal inhibitory concentration: 3750 nM
Compound 3: middle estimate off by 1.1-fold (0.06 log units), on the low side, and the stated range covers the measured number.
By their numbers in this assay, from the lowest: compounds 1, 2 and 3 (each within the scatter of the next).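

Replacing fluoro with trifluoromethyl on an aromatic carbon in this assay gives a step within the scatter (a 1.2-fold higher number from compound 1 to compound 3 (0.07 log units; within the scatter)), and the change from 3-fluorobenzyl to 4-(trifluoromethyl)benzyl does the same (a 1.1-fold higher number from compound 2 to compound 3 (0.03 log units; within the scatter)). Compounds 1, 2 and 3 therefore stand level, so this position has now taken a group with more heavy atoms, as well as a shift of the fluorophenyl substitution, without a step beyond the scatter. No measured evidence bears on why these values stay level.

All three groups are halogen-bearing phenyl rings with no hydrogen-bond donors or acceptors, so the compounds shown leave open whether an amine or a carboxylic acid on this ring would give a step beyond the scatter. Going by these compounds, the effect of a plain unsubstituted phenyl or a longer chain in place of the benzyl group also remains open.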